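The compounds below may be only part of what the source reports. "The series", "measured", "known", "first", "only" and "open" are said of these compounds alone.

Compound 1 `CC(C)N(CCN(C(=O)Nc1ccc(F)c(F)c1)C1CC[C@]2(c3cccc(Br)c3)CC2C1)C(C)C` gives 7.76 nM in a functional assay for antagonist activity at melanin-concentrating hormone receptor 1 (Homo sapiens); on this read-out lower numbers stand for stronger inhibition and higher numbers for weaker inhibition.
Compound 2 `CC(C)N(CCN(C(=O)Nc1ccc(F)c(Cl)c1)C1CC[C@]2(c3cccc(CN4CC[C@H](O)C4)c3)CC2C1)C(C)C` gives 21 nM in this assay.
Compound 3 `CC(C)N(CCN(C(=O)Nc1cc(Cl)nc(Cl)c1)C1CC[C@]2(c3cccc(C#N)c3)CC2C1)[C@@H](C)CO` gives 1.6 nM in this assay.

Of the three, compound 3 has the lowest number in this assay, and its gap to compound 1 as well as to compound 2 lies beyond the usual scatter of repeated measurements, so compound 3 is the strongest inhibitor of this small set. Compound 4 `CC1CC[C@@H](CO)N1CCN(C(=O)Nc1cc(Cl)nc(Cl)c1)C1CC[C@]2(c3cccc(C#N)c3)CC2C1` keeps the core of compound 3 and changes only the amine end of the chain: 2-(hydroxymethyl)-5-methylpyrrolidin-1-yl in place of (1-(hydroxymethyl)ethyl)(isopropyl)amino on a saturated chain carbon, two bonds along the chain from an amide-type nitrogen. The leaving group and the entering group are built from the same count of atoms, with the same donors and acceptors; the difference is that in compound 4 these atoms are tied into a ring. Among the measured compounds shown here, no measured pair here shows what such a ring closure does, so the expectation rests on the unchanged rest of the molecule. A step that stays within the scatter, or at most a modest rise, is expected, which gives a 1.6-fold higher number from compound 3 to compound 4 (0.19 log units; within the scatter). Compound 4 is therefore expected to give about 2.5 nM in this assay, with a range from 0.8 nM to 8 nM.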

Compound 4, inhibition constant: 1.2 nM
Compound 4: middle estimate off by 2.1-fold (0.32 log units), on the high side; measured number inside the range.
By their numbers in this assay, from the lowest: compounds 4 and 3 (each within the scatter of the next); then compound 1; then compound 2.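

Among the compounds shown here, the step of a 1.3-fold lower number from compound 3 to compound 4 (0.12 log units; within the scatter) in this assay lies within the scatter, and it is the first comparison here that changes only the amine end of the chain. On a saturated chain carbon, two bonds along the chain from an amide-type nitrogen, the open (1-(hydroxymethyl)ethyl)(isopropyl)amino group and the ring-closed 2-(hydroxymethyl)-5-methylpyrrolidin-1-yl therefore cannot be told apart on this read-out, so tying these atoms into a five-membered ring is compatible with a low number. Nothing shown explains why the two groups read alike.

The compounds shown leave open how a plain pyrrolidin-1-yl, carrying neither the hydroxymethyl nor the methyl, would read at this place. They also leave open the outcome for a six-membered piperidin-1-yl, or for a carboxylic acid in place of the hydroxymethyl.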